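Compound 4: a New Group in Place of Diethylamino

The compounds below may be only part of what the source reports. "The series", "measured", "known", "first", "only" and "open" are said of these compounds alone.

The measured compounds, in an in vitro assay on 293-EBNA cells for binding affinity to corticotropin-releasing factor receptor 1 (Homo sapiens); a higher number here means a weaker inhibitor, a lower number a stronger inhibitor:
Compound 1, `CCCC(C)Nc1nc(C)nc2c1nnn2-c1c(C)cc(C)cc1C`, gives 7.1 nM.
Compound 2, `CCN(CC)c1nc(C)nc2c1nnn2-c1ccc(C(C)C)cc1Br`, gives 25.3 nM.
Compound 3, `CCCCN(CC)c1nc(C)nc2c1nnn2-c1ccc(N(C)C)cc1C(F)(F)F`, gives 15.4 nM.

Compound 2 carries the highest number of the three. Compound 3 stands within the scatter of it, while compound 1 sits a step lower that lies beyond the scatter. Compound 4, `COCC(COC)Oc1nc(C)nc2c1nnn2-c1ccc(C(C)C)cc1Br`, differs from compound 2 in one place: a group of 8 heavy atoms (5 carbon, 3 oxygen; no ring) in place of a group of 5 heavy atoms (4 carbon, 1 nitrogen; no ring), on an aromatic carbon. For the measured compounds named here, no pair of measured compounds isolates a change of this kind, so the expectation rests on compound 2 alone. In this assay a modest step toward a higher number is expected, possibly none beyond the scatter, giving a 1.6-fold higher number from compound 2 to compound 4 (0.20 log units; within the scatter). Compound 4 is therefore estimated at 40 nM, in the range 10 nM to 160 nM.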

Compound 4, inhibition constant: 7.1 nM
The estimate for compound 4 lay 5.6-fold (0.75 log units) above the measured number; the measured number lies below the stated range.
By their numbers in this assay, from the lowest: compounds 1 and 4 (each within the scatter of the next); then compounds 3 and 2 (each within the scatter of the next).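

In this assay, replacing diethylamino on this aromatic carbon with the larger open-chain ether group gives a 3.6-fold lower number from compound 2 to compound 4 (0.55 log units; beyond the scatter). For the compounds shown here, compound 4 thus shows that no nitrogen is needed at this carbon, which the earlier compounds, all attached there through nitrogen, could not show. Nothing shown here accounts for the step. As far as these compounds go, it remains open whether the linking oxygen or the two methoxymethyl arms carry the step, a question that an isopropoxy group, or the same arms on an amine nitrogen, would separate.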